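The source may report more compounds than this note shows. Statements on the series, on what has been measured and on what is new or still open speak of the compounds shown alone.

Measured so far in a functional assay on SK-N-SH cells (Homo sapiens) for cytotoxicity, read by MTT assay, with a stated time of 24 h; on this read-out higher numbers stand for weaker inhibition and lower numbers for stronger inhibition:
- compound 1 `COc1cc(/C=C(\C#N)C(=O)N/N=C(\C)c2c(O)c3ccc(O)cc3oc2=O)ccc1O`: 14400 nM
- compound 2 `C/C(=N\NC(=O)/C(C#N)=C/c1ccc(N(C)C)cc1)c1c(O)c2ccc(O)cc2oc1=O`: 6090 nM

Among the compounds with values here, of these two, compound 2 has the lower number, at 6090 nM, and its only neighbour is compound 1 at 14400 nM.

The next change leads to compound 3 `C/C(=N\NC(=O)/C(C#N)=C/c1ccc([N+](=O)[O-])cc1)c1c(O)c2ccc(O)cc2oc1=O`, with nitro in place of dimethylamino on an aromatic carbon, para to a large group: nitro in place of dimethylamino on an aromatic carbon.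

Within the data shown here, only one measured step bears on this. It also changes the group at this end of the molecule, giving a 2.4-fold lower number from compound 1 to compound 2 (0.37 log units; beyond the scatter), a modest move. Among the measured compounds shown here, no measured compound carries nitro, so the direction in this assay rests on thin evidence, and a single step sets only a rough scale. A step no larger than that modest one is expected, with a slight lean back toward the number of compound 1.

The expected move is small and toward a higher number, a 1.5-fold higher number from compound 2 to compound 3 (0.17 log units; within the scatter).

For compound 3 the estimated value is 9000 nM, with an expected range from 2800 nM to 28000 nM.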

Compound 3, half-maximal inhibitory concentration: 10300 nM
For compound 3 the middle estimate is 1.1-fold (0.06 log units) below the measured one; low and high end bracket the measured number.
By their numbers in this assay, from the lowest: compounds 2, 3 and 1 (each within the scatter of the next, the first and the last beyond it).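

In this assay, nitro in place of dimethylamino on an aromatic carbon, para to a large group, gives a 1.7-fold higher number from compound 2 to compound 3 (0.23 log units; within the scatter), so this exchange does not separate the two compounds on this read-out. Against the 4-hydroxy-3-methoxyphenyl end, 4-nitrophenyl gives a 1.4-fold lower number from compound 1 to compound 3 (0.15 log units; within the scatter), which is also unresolved, so compound 3 cannot be told apart from either neighbour, and of the three pairs only a 2.4-fold lower number from compound 1 to compound 2 (0.37 log units; beyond the scatter) stands beyond the scatter. Nothing available on these groups accounts for this result, and no cause can be assigned to it.

From the compounds shown here alone, whether any group at this aromatic carbon can move the number clearly beyond the spread of these three compounds remains open, for example a carboxylic acid, a primary amine or a single fluorine atom in place of nitro. The shared core and the nitrile stay the same in compound 1, compound 2 and compound 3, so what those parts contribute, and whether these numbers reflect anything specific to this cell line, cannot be read from this set.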